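Oxazole to butyl-imidazole swap on the piperazine benzimidazole series

This account rests on a few compounds, and the source may have more. Where it says the series, first, only, none or still open, it means among the compounds named here.

Measured compounds:
- compound 1 `Cc1nc(CN2CCN(c3cccc4[nH]c(-c5ccc(C(C)(C)C)cc5)nc34)CC2)c[nH]1` — 7.5 nM
- compound 2 `Cc1nc(C)c(CN2CCN(c3cccc4[nH]c(-c5ccc(C(C)(C)C)cc5)nc34)CC2)o1` — 31 nM
- compound 3 `CCCn1cnc(CN2CCN(c3cccc4[nH]c(-c5ccc(C(C)(C)C)cc5)nc34)CC2)c1C` — 12 nM

All three were run in an assay on isolated protein for displacement of a labelled ligand from Gonadotropin-releasing hormone receptor (Homo sapiens); on this read-out lower numbers stand for stronger inhibition and higher numbers for weaker inhibition. On these numbers compound 2 stands at the highest value of the three: compound 3 is its nearest neighbour, and compound 1 is furthest from it, both beyond the scatter. Both steps away from the 2,4-dimethyl-1,3-oxazol-5-yl group run in the same direction: a 4.1-fold higher number from compound 1 to compound 2 (0.62 log units; beyond the scatter) and a 2.6-fold lower number from compound 2 to compound 3 (0.41 log units; beyond the scatter), whereas the two imidazole-bearing compounds sit within the scatter of each other (a 1.6-fold higher number from compound 1 to compound 3 (0.20 log units; within the scatter)).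

Compound 4 `CCCCc1nc(CN2CCN(c3cccc4[nH]c(-c5ccc(C(C)(C)C)cc5)nc34)CC2)cn1C` has not yet been measured. It differs from compound 2 by 2-butyl-1-methyl-1H-imidazol-4-yl in place of 2,4-dimethyl-1,3-oxazol-5-yl on a saturated chain carbon bound to an amine nitrogen in a ring. This is the third variant in which a five-membered aromatic ring with two hetero atoms sits on the saturated chain carbon bound to the amine nitrogen in the ring; the two imidazole cases so far both gave lower numbers than the oxazole. The bearing steps are therefore those from compound 2 to its imidazole neighbours, modest in size. A modest drop in this assay is expected, with compound 4 estimated at 10 nM (range 4 nM to 28 nM), corresponding to an expected 3.1-fold lower number from compound 2 to compound 4 (0.49 log units; beyond the scatter).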

Compound 4, half-maximal inhibitory concentration: 26 nM
The estimate for compound 4 lay 2.6-fold (0.41 log units) below the measured number; the range from low to high includes it.
By their numbers in this assay, from the lowest: compounds 1 and 3 (each within the scatter of the next); then compounds 4 and 2 (each within the scatter of the next).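

In this assay, an imidazole in this place no longer separates from the oxazole as a matter of course: a 1.2-fold lower number from compound 2 to compound 4 (0.08 log units; within the scatter), so compound 4 goes against the lower numbers seen for the two earlier imidazole cases. The substituents on the imidazole now prove to count at this position on the saturated chain carbon bound to the ring amine nitrogen, with a 2.2-fold higher number from compound 3 to compound 4 (0.34 log units; beyond the scatter) and a 3.5-fold higher number from compound 1 to compound 4 (0.54 log units; beyond the scatter), so that 2-butyl-1-methyl-1H-imidazol-4-yl stands apart from both 5-methyl-1-propyl-1H-imidazol-4-yl and 2-methyl-1H-imidazol-4-yl, and the ring type alone does not set the number. Nothing at hand accounts for these differences among the imidazoles.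

The imidazole groups in compounds 1, 3 and 4 differ in more than one substituent at once, so the compounds shown do not separate the contribution of the butyl chain from that of the methyl groups. Still open, as far as these compounds go, is how an ethyl chain in place of the butyl chain would read, or a butyl chain ending in an amine or a carboxylic acid.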